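Methyl for methoxy on a core sitting at the limit

This account rests on a few compounds, and the source may have more. Where it says the series, first, only, none or still open, it means among the compounds named here.

Compound 1 `C=C1C[C@]23C[C@@]1(O)CC[C@H]2c1cc(Br)c(O)c(C)c1[C@@H]3Cn1cc(-c2ccc(OC)cc2)nn1` is tested in a functional assay on SMMC-7721 cells (Homo sapiens) for cytotoxicity, read by MTT assay, with a stated time of 4 days; on this read-out higher numbers stand for weaker inhibition and lower numbers for stronger inhibition. In this assay compound 1 reaches only the limit > 20000 nM. Compound 2 `C=C1C[C@]23C[C@@]1(O)CC[C@H]2c1ccc(O)c(C)c1[C@@H]3Cn1cc(-c2ccc(OC)cc2)nn1` carries hydrogen in place of bromo on an aromatic carbon. In this assay compound 2 also gives only the limit > 20000 nM. The step that the two limits leave unreadable from compound 1 to compound 2 is unreadable because of the limit of > 20000 nM in this assay, at which 2 of the 2 values shown sit. Compound 3 `C=C1C[C@]23C[C@@]1(O)CC[C@H]2c1cc(Br)c(O)c(C)c1[C@@H]3Cn1cc(-c2ccc(C)cc2)nn1` carries methyl in place of methoxy on an aromatic carbon, methyl in place of methoxy on an aromatic carbon. Among the measured compounds shown here, no measured step bears on this change, and compound 1 stands at a limit, so no readable step is expected. Compound 3 is expected to give 20000 nM, between 5000 nM and 50000 nM. The expected step is a number no higher from compound 1 to compound 3 (the limit leaves the size open).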

Compound 3, half-maximal inhibitory concentration: > 20000 nM
Compound 3: only a limit was reported (the forecaster's own chance of this, stated with the estimate: 75%); the middle value sits exactly at the limit.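

No step can be read from compound 1 to compound 3, because both give only a limit: the limit of > 20000 nM in this assay, at which 3 of the 3 values shown sit. The compounds shown leave open whether methyl in place of methoxy changes the result in this assay at all.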